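A few compounds are considered here, and "the series" means these few. Any claim that something is new, unique, unknown or untested is made for them only; others in the source may bear on it.

Compound 1: `[O-][S+](CCNC1CCN(Cc2ccc(F)cc2)CC1)C(c1ccc(F)cc1)c1ccc(F)cc1`, 26.5 nM
Compound 2: `Fc1ccc(C(SCCNC2CCN(CC3CC3)CC2)c2ccc(F)cc2)cc1`, 269 nM

Of the compounds shown here, two have been measured in an assay on membranes from Cortex for displacement of a labelled ligand from Sigma non-opioid intracellular receptor 1 (Cavia porcellus), read by scintillation counting, with a stated time of 120 min; a higher number here means a weaker inhibitor, a lower number a stronger inhibitor. Compound 1 has the lower of the two numbers and is the stronger inhibitor; compound 2 gives 269 nM, a gap beyond the scatter. Compound 3, `CC(C)(C)C(=O)N1CCC(NCC[S+]([O-])C(c2ccc(F)cc2)c2ccc(F)cc2)CC1`, awaits measurement. It differs from compound 1 in one place: (tert-butyl)carbonyl in place of 4-fluorobenzyl on an amine nitrogen in a ring. For the measured compounds named here, no single-change step between measured compounds is available, so the expectation rests on compound 1 alone. The expected step is a 7.5-fold higher number from compound 1 to compound 3 (0.88 log units; beyond the scatter), toward a weaker inhibitor and beyond the scatter. Compound 3 is estimated at 200 nM, between 40 nM and 1000 nM.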

Compound 3, inhibition constant: 11200 nM
Compound 3: middle estimate off by 56-fold (1.75 log units), on the low side; measured number above the stated range.
By their numbers in this assay, from the lowest: compound 1; then compound 2; then compound 3.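

In this assay, putting (tert-butyl)carbonyl in place of 4-fluorobenzyl on an amine nitrogen in a ring gives a 420-fold higher number from compound 1 to compound 3 (2.63 log units; beyond the scatter), so the group on this nitrogen strongly affects the measured number. This single change removes an aromatic ring and brings in a carbonyl with one hydrogen-bond acceptor, and the step cannot separate these two differences. Nothing measured here explains the loss.

The compounds shown leave open which difference matters more. A benzoyl group on this nitrogen would keep the aromatic ring alongside a carbonyl, while a neopentyl group would keep the tert-butyl without one.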